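Chloro for Phenoxy on the Weaker of Two Thiazolones

The source may hold more compounds than are shown below. What is called first, only, known or untested is meant among the compounds shown, and "the series" means these compounds.

Among the measured compounds shown here, compound 1 `COc1ccc(/C=C2\SC(c3ccc(Oc4ccccc4)cc3)=NC2=O)c2ccccc12` is one of two compounds measured in an assay on cells for inhibition of Polyunsaturated fatty acid 5-lipoxygenase (Homo sapiens), read by HPLC, with stated times of 15 min and 10 min (a lower number here means a stronger inhibitor, a higher number a weaker inhibitor), and in that assay compound 1 gives 2150 nM. The other, compound 2 `COc1ccc(/C=C2\SC(c3ccc4ccccc4c3)=NC2=O)cc1`, gives 120 nM in this assay, so compound 1 stands as the higher of the two numbers, well beyond the scatter. Compound 3 `COc1ccc(/C=C2\SC(c3ccc(Cl)cc3)=NC2=O)c2ccccc12` has not yet been measured; it differs from compound 1 by chloro in place of phenoxy on an aromatic carbon. For the measured compounds named here, with no measured step between such a pair to lean on, the change from compound 1 to compound 3 is expected to give a 1.8-fold lower number from compound 1 to compound 3 (0.25 log units; within the scatter), a modest move toward a lower number that may not clear the scatter. Compound 3 is therefore estimated at 1200 nM, within 300 nM to 5000 nM.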

Compound 3, half-maximal inhibitory concentration: 640 nM
For compound 3 the middle estimate is 1.9-fold (0.27 log units) above the measured one; low and high end bracket the measured number.
By their numbers in this assay, from the lowest: compound 2; then compound 3; then compound 1.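

Chloro in place of phenoxy on this aromatic carbon, para to a large group, gives a 3.4-fold lower number from compound 1 to compound 3 (0.53 log units; beyond the scatter) in this assay. The six-membered aromatic ring of the phenoxy is therefore not needed at this position for inhibition, and a single chlorine atom serves better on this core. Nothing available here accounts for the gain. Left open is how an amine, a carboxylic acid or a longer chain on this carbon would compare with chloro, and whether the same change would give a similar step on another core.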